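This account rests on a few compounds, and the source may have more. Where it says the series, first, only, none or still open, it means among the compounds named here.

Three compounds sharing one core were taken into a physicochemical assay for lipophilicity, read by HPLC, using the shake flask method, in phosphate buffer, measured as octanol-water partition, with a stated time of 24 h, at pH 7.4, tested at 100 uM; on this read-out higher numbers stand for higher lipophilicity and lower numbers for lower lipophilicity. Going by the values given here, compound 2 (`O=C(O)CC1COc2cc(OCc3cn(-c4cccc(Cl)c4)nn3)ccc21`) gives 1.09, the only number in the set. For compound 1 (`O=C(O)CC1COc2cc(OCc3cn(-c4ccccc4Cl)nn3)ccc21`) the entry reads "not determined" (no result reported). For compound 3 (`O=C(O)CC1COc2cc(OCc3cn(-c4ccc(OCc5ccccc5)cc4)nn3)ccc21`) the entry reads "not determined" (no result reported). Compound 2 therefore cannot be ranked against either neighbour, and its value stands alone as the single reference point.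

Still unmeasured in this assay is compound 4 (`O=C(O)CC1COc2cc(OCc3cn(-c4c(Cl)cccc4Cl)nn3)ccc21`). It differs from compound 2 by 2,6-dichlorophenyl in place of 3-chlorophenyl on an aromatic nitrogen of a five-membered aromatic ring with 3 nitrogen: 2,6-dichlorophenyl in place of 3-chlorophenyl on an aromatic nitrogen. Among the compounds with values here, no measured pair shows what a change of this kind does on this read-out, so the expectation rests on the structural change alone. A modest upward step is expected, a little larger than the usual scatter, although the expected range also takes in values within the scatter of compound 2. The estimated size of the change is a number 0.36 log units higher from compound 2 to compound 4 (beyond the scatter). For compound 4 the expected value is 1.45, with an estimated range from 1 to 1.9.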

Compound 4, distribution coefficient: 1.96
Compound 4: middle estimate off by 0.51 log units, on the low side; measured number outside the range, above it.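

In this assay, replacing 3-chlorophenyl with 2,6-dichlorophenyl on an aromatic nitrogen of the five-membered ring gives the set its first readable step, showing a number 0.87 log units higher from compound 2 to compound 4 (beyond the scatter). This shows that the read-out responds to a change at this position, and that the response can exceed the usual scatter even though neither group carries a hydrogen-bond donor, a hydrogen-bond acceptor or a net charge. No supporting evidence is available to account for the step.

Going by these compounds alone, because the change both adds a chlorine and alters where the chlorine atoms sit, this single pair cannot separate the two, and no step to compound 1 or compound 3 can be read, as their entries hold no number. Also open is how the read-out would respond at this position to a group of another kind in place of the chlorinated phenyl rings, such as an amine or a methoxy group, since every number shown comes from a chlorinated phenyl ring at this position.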